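A few compounds are considered here, and "the series" means these few. Any claim that something is new, unique, unknown or untested is made for them only; others in the source may bear on it.

Measured compounds:
- compound 1, `COc1cccc(COc2ccc3cc(C(=O)/C=C/c4cc(OC)ccc4OC)c(=O)oc3c2)c1`: > 100000 nM
- compound 2, `COC(=O)c1ccc(/C=C/C(=O)c2cc3ccc(O)cc3oc2=O)cc1`: 4400 nM

In a functional assay on K562 cells (Homo sapiens) for cytotoxicity, read by MTT assay, with a stated time of 72 h (on this read-out higher numbers stand for weaker inhibition and lower numbers for stronger inhibition), compound 1 gives > 100000 nM, which is a limit of the assay and not a number. Compound 2, `COC(=O)c1ccc(/C=C/C(=O)c2cc3ccc(O)cc3oc2=O)cc1`, gives 4400 nM in this assay. Among the compounds with values here, compound 1 stands only at the limit of > 100000 nM in this assay, at which 1 of the 2 values shown sits, so its place on the scale is not a point; no step between measured compounds is available in this set, and the two compounds differ in more than one place, so their values are recorded side by side without a step.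

Compound 3, `COc1cccc(COc2ccc3cc(C(=O)/C=C/c4ccccc4)c(=O)oc3c2)c1`, is the not yet measured member. Against compound 1 the change is phenyl in place of 2,5-dimethoxyphenyl on a double-bonded chain carbon bound to a double-bonded chain carbon. Nothing measured here tells how that change shifts this assay; compound 1 itself is defined only by its limit. The step from compound 1 to compound 3 in this assay is expected to be small, at most a shift towards stronger inhibition off the limit, and no larger than an at least 1.4-fold lower number from compound 1 to compound 3 (0.15 log units; that floor lies within the scatter). Compound 3 is therefore estimated at 70000 nM in this assay, with a range from 20000 nM to 300000 nM, and with a fair chance that only a limit is reported again.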

Compound 3, half-maximal inhibitory concentration: > 100000 nM
Compound 3 was reported as a limit (the forecaster's own chance of this, stated with the estimate: 60%); middle value at least 1.4-fold (0.15 log units) away from the limit.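

No step can be read from compound 1 to compound 3 in this assay, as each of the two is reported only as a limit and not as a number: the limit of > 100000 nM in this assay, at which 2 of the 3 values shown sit.

The compounds shown leave open how far either lies beyond that limit, and whether phenyl in place of 2,5-dimethoxyphenyl changes the read-out in this assay at all.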